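The source may report more compounds than this note shows. Statements on the series, on what has been measured and on what is new or still open speak of the compounds shown alone.

Compound 1, with the structure `COc1ccccc1C1CCN(CC(=O)Nc2cccc(C)c2)CC1`, is measured in a functional assay on HEK293 cells for agonist activity at D(4) dopamine receptor (Homo sapiens), read by FLIPR (a lower number here means a smaller maximal response, a higher number a larger maximal response), where compound 1 gives 43%. That number sits at the low end of the three values shown. Compound 2, with the structure `O=C(NCN1CCC(c2cccc[n+]2[O-])CC1)c1cnccc1Cl`, gives 44%, a value that cannot be told apart from that of compound 1 within the usual scatter of this assay. Compound 3, with the structure `O=C(CN1CCC(c2cccc[n+]2[O-])CC1)Nc1ccc(F)cc1F`, gives 74%, which lies clearly higher than compound 1, beyond the scatter.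

The next compound, compound 4, has the structure `Cc1cccc(NC(=O)CN2CCC(c3ccccc3F)CC2)c1`. It differs from compound 1 in one place: fluoro in place of methoxy on an aromatic carbon. Among the compounds with values here, no pair of measured compounds differs by this same change, so there is no measured step to lean on. Because compound 1 gives 43% and nothing measured shows how this exchange moves the response, the expected step from compound 1 to compound 4 is small, a number 5 percentage points higher from compound 1 to compound 4 (within the scatter), not beyond the scatter in either direction. The estimate for compound 4 is therefore 48%, with a range from 28% to 68%.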

Compound 4, largest response reached (reported as efficacy), in percent of the reference or control that the assay uses: 57%
Estimate against measurement, compound 4: 9 percentage points below; measured number inside the range.
By their numbers in this assay, from the lowest: compounds 1 and 2 (each within the scatter of the next); then compound 4; then compound 3.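

Exchanging methoxy for fluoro on the aromatic ring, ortho to a large group, gives in this assay a number 14 percentage points higher from compound 1 to compound 4 (beyond the scatter). Within the data shown here, this is the first measured step at this position, and it shows that the maximal response changes with the group placed there, here as 2-methoxyphenyl becomes 2-fluorophenyl. Nothing available explains this shift in the response.

With methoxy and fluoro alone, the exchange removes a carbon and a hydrogen-bond acceptor at once, so the effect of either cannot be separated from the other. As far as these compounds go, it remains open how the response would change with hydroxyl, ethoxy or trifluoromethyl at this place, and whether fluoro in place of methoxy would give a similar step on a different core.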